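A Ring Swap on a Weak HEK293 Inhibitor

The source may report more compounds than this note shows. Statements on the series, on what has been measured and on what is new or still open speak of the compounds shown alone.

Two related compounds have been tested in an ADME assay on HEK293 cells (Homo sapiens) for inhibition, read by MTT assay, with stated times of 18 h and 4 h; a lower number here means a stronger inhibitor, a higher number a weaker inhibitor. Compound 1 `CCCCCCCCCCCCCCCCOP(=O)(O)OCCSC(=S)N1CCCCCC1` gives no number in this test, only the limit > 100000 nM. Among the measured compounds shown here, compound 2 `CCCCCCCCOP(=O)(O)OCCSC(=S)N1CCN(C)CC1` gives 86000 nM, which is the only actual number available, and so there is no measured series against which to place it.

Compound 3 `CCCCCCCCOP(=O)(O)OCCSC(=S)N1CCCCCC1` has not yet been measured. It is compound 2 with azepan-1-yl in place of 4-methylpiperazin-1-yl on a thiocarbonyl carbon. The azepan-1-yl group also occurs in compound 1, but that compound differs from compound 3 elsewhere as well, and its limit gives no size for this change.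

For the measured compounds named here, no measured step isolates this exchange, so the expectation rests on compound 2 at 86000 nM. Only a small shift towards stronger inhibition is expected, one that stays within the usual scatter, and a result at the limit of the test would not be surprising. The expected change is a 1.4-fold lower number from compound 2 to compound 3 (0.16 log units; within the scatter). Compound 3 is estimated at 60000 nM, with an expected range of 20000 nM to 100000 nM.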

Compound 3, half-maximal inhibitory concentration: > 100000 nM
Compound 3: no number, only a limit (the forecaster's own chance of this, stated with the estimate: 30%); middle value at least 1.6-fold (0.22 log units) away from the limit.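

In this assay, azepan-1-yl in place of 4-methylpiperazin-1-yl on a thiocarbonyl carbon gives an at least 1.1-fold higher number from compound 2 to compound 3 (0.06 log units; that floor lies within the scatter) and so brings no gain in inhibition at this position. Compound 3 has only a limit, so this step has a floor and no measured size, and the exchange may matter little or a great deal. Compound 1 and compound 3 both end at limits, so the step between them cannot be read, and the two azepan-1-yl compounds give no number to set against compound 2: the limit of > 100000 nM in this assay, at which 2 of the 3 values shown sit.

From the compounds shown here alone, it remains open whether a morpholine ring or a simple dimethylamino group on the thiocarbonyl carbon would give a readable number in this assay, and whether a longer chain on the 4-methylpiperazin-1-yl compound would move the value of compound 2 from 86000 nM in either direction. With a single number in the set, the compounds shown support no trend for either the ring or the chain.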